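A few compounds are considered here, and "the series" means these few. Any claim that something is new, unique, unknown or untested is made for them only; others in the source may bear on it.

Compound 1, `COc1ccc(OC)c(-c2nc(C(c3ccccc3)c3ccccc3)sc2CC(=O)O)c1`, is the starting point of this series. In an in vitro functional assay on HEK285-7 cells for antagonist activity at prostaglandin D2 receptor 2 (Homo sapiens), read by BRET and beta-arrestin recruitment (a lower number here means a smaller maximal response, a higher number a larger maximal response), compound 1 reaches 80%. Compound 2, `O=C(O)Cc1sc(C(c2ccccc2)c2ccccc2)nc1-c1cccc(F)c1`, keeps the shared core and swaps the ring group on the core for another; in this assay compound 2 reaches 80%, and the step from compound 1 to compound 2 is no change at the digits printed from compound 1 to compound 2 (within the scatter). Going by the values given here, compound 2 therefore stands level with compound 1, the only other measured compound. Compound 3, `O=C(O)Cc1sc(C(c2ccccc2)c2ccccc2)nc1-c1ccc(C(F)(F)F)cc1`, is not yet measured. It differs from compound 2 at the same place: 4-(trifluoromethyl)phenyl in place of 3-fluorophenyl on an aromatic carbon. Among the compounds with values here, the one measured step that bears on this change, the swap of the ring group from compound 1 to compound 2, stayed within the scatter. With that single precedent, the expected step in this assay is no change at the digits printed from compound 2 to compound 3 (within the scatter), that is none beyond the scatter. Compound 3 is thus expected to reach about 80%, estimated between 65% and 95%.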

Compound 3, largest response reached (reported as efficacy), in percent of the reference or control that the assay uses: 80%
For compound 3 middle estimate and measured number coincide at the digits printed, and the stated range covers the measured number.
By their numbers in this assay, from the lowest: compounds 1, 2 and 3 (each within the scatter of the next).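

In this assay, replacing 3-fluorophenyl with the larger 4-(trifluoromethyl)phenyl, which has 10 heavy atoms rather than 7, gives a second flat result at this aromatic carbon of the core (no change at the digits printed from compound 2 to compound 3 (within the scatter)). The comparison with the starting compound is flat too (no change at the digits printed from compound 1 to compound 3 (within the scatter)), so three differently substituted phenyl rings at this place give maximal responses that cannot be told apart. No supporting measurement accounts for this flat result.

On these data alone, all three groups at this place are substituted phenyl rings, so it remains open whether a phenyl ring carrying an amine or a carboxylic acid, or a longer alkyl chain in place of the ring, would leave the response unchanged. The largest response also leaves open how much of each compound is needed to reach it.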